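A few compounds are considered here, and "the series" means these few. Any claim that something is new, unique, unknown or untested is made for them only; others in the source may bear on it.

Working notes on the series. For the measured compounds named here, in an assay (Rattus norvegicus) for inhibition of Fatty-acid amide hydrolase 1 (Homo sapiens) (on this read-out lower numbers stand for stronger inhibition and higher numbers for weaker inhibition), compound 2 `Cc1ccc(-c2cnc(C(=O)CCCCCCc3ccccc3)o2)nc1` gives 2.8 nM, the lowest of the two numbers measured so far. Compound 1 `Nc1ccccc1-c1cnc(C(=O)CCCCCCc2ccccc2)o1` gives 750 nM in this assay. Going by the values given here, the one measured step, a 270-fold lower number from compound 1 to compound 2 (2.43 log units; beyond the scatter), exchanges one aryl group for another and is the only step recorded.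

Compound 3 `Cc1cccc(-c2cnc(C(=O)CCCCCCc3ccccc3)o2)n1` is not yet measured in this assay. It differs from compound 2 in one place: 6-methylpyridin-2-yl in place of 5-methylpyridin-2-yl on an aromatic carbon. Among the compounds with values here, the only measured step concerns the exchange of a whole aryl group and does not bear directly on a change in which the same atoms are joined differently within the pyridinyl group, so its size is no guide here. Within the data shown here, with no comparable step recorded, a change of modest size is expected, direction uncertain, and compound 3 is estimated to give 6 nM in this assay, within a range of 1.5 nM to 25 nM, which would mean a step of a 2.1-fold higher number from compound 2 to compound 3 (0.33 log units; beyond the scatter).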

Compound 3, inhibition constant: 3.3 nM
Beside the measured number, compound 3's estimate is 1.8-fold (0.26 log units) above it, within the range that was stated.
By their numbers in this assay, from the lowest: compounds 2 and 3 (each within the scatter of the next); then compound 1.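

In this assay, moving the methyl group from 5-methylpyridin-2-yl to 6-methylpyridin-2-yl on this aromatic carbon of the core gives a 1.2-fold higher number from compound 2 to compound 3 (0.07 log units; within the scatter), so this assay does not separate the two methylpyridinyl isomers. The large distance from the aminophenyl compound also holds for the second isomer, with a 230-fold lower number from compound 1 to compound 3 (2.36 log units; beyond the scatter), so it is not confined to the 5-methylpyridin-2-yl group. Nothing available explains why the two isomers read alike.

The compounds shown leave open whether the methyl group contributes at all, as an unsubstituted pyridin-2-yl group or a pyridin-2-yl group bearing a carboxylic acid would test. For the compounds shown here, they also include no compound with a plain phenyl group. Such a compound would allow the amine and the ring nitrogen to be looked at separately.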